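A few compounds are considered here, and "the series" means these few. Any claim that something is new, unique, unknown or untested is made for them only; others in the source may bear on it.

Measured compounds:
compound 1 `O=C1NCCN1c1ccc(S(=O)(=O)Nc2ccc(F)c(F)c2)cc1` — 350 nM
compound 2 `CC(C)Cc1ccc(NS(=O)(=O)c2ccc(N3CCNC3=O)cc2)cc1` — > 1000 nM

These two compounds share a core and differ only in the aryl group on the sulfonamide nitrogen. For the measured compounds named here, in a functional assay on HT-29 cells (Homo sapiens) for antiproliferative activity, read by sulforhodamine B assay, with a stated time of 48 h (a higher number here means a weaker inhibitor, a lower number a stronger inhibitor), compound 1 gives 350 nM, the only actual number in this set. Compound 2 gives > 1000 nM in this assay, which is a limit rather than a number. Compound 1 therefore stands as the sole measured point, with the other value sitting at the limit of > 1000 nM in this assay, at which 1 of the 2 values shown sits.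

Compound 3 `Cc1ccc(NS(=O)(=O)c2ccc(N3CCNC3=O)cc2)cc1` has not yet been measured. It differs from compound 1 in one place: 4-methylphenyl in place of 3,4-difluorophenyl on a sulfonamide nitrogen. Going by the values given here, no step between measured compounds shows what this exchange does, so the direction has to be guessed. Compound 2, which also carries an alkyl-substituted phenyl instead of the difluorophenyl, sits at the limit of > 1000 nM in this assay, at which 1 of the 2 values shown sits. The step from compound 1 to compound 3 is expected to weaken inhibition, a 2.6-fold higher number from compound 1 to compound 3 (0.41 log units; beyond the scatter), beyond the scatter. Compound 3 is estimated at 900 nM, with a likely range from 300 nM to 3000 nM.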

Compound 3, half-maximal inhibitory concentration: 480 nM
Compound 3: the middle estimate sits 1.9-fold (0.27 log units) above what was measured, within the range that was stated.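

In this assay, 4-methylphenyl can stand in place of 3,4-difluorophenyl on the sulfonamide nitrogen without a change beyond the scatter: a 1.4-fold higher number from compound 1 to compound 3 (0.14 log units; within the scatter). The fluorines are therefore not required for this level of activity, whereas the alkyl chain on the aromatic ring does make a difference, as hydrogen in place of isopropyl on a saturated chain carbon bound to an aromatic carbon gives an at least 2.0-fold lower number from compound 2 to compound 3 (0.31 log units; beyond the scatter). That step has only a lower bound, as the value for compound 2 is a limit and not a number: the limit of > 1000 nM in this assay, at which 1 of the 3 values shown sits.

As far as these compounds go, whether an amine or a carboxylic acid in place of the methyl of compound 3 would keep this activity remains open. It is also unknown how a single fluorine, or an unsubstituted phenyl, would compare at this position.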